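Alkoxyphenyl versus chlorophenyl on the chalcone carbonyl

The source may hold more compounds than are shown below. What is called first, only, known or untested is meant among the compounds shown, and "the series" means these compounds.

Measured so far:
compound 1, `CCCCCCCCCCCCOc1ccc(C(=O)/C=C/c2c(/C=C/c3ccc(OC)cc3)cc(OC)cc2OC)cc1`, 12.7 ug/mL
compound 2, `CCCC(C)Oc1ccc(C(=O)/C=C/c2c(/C=C/c3ccc(OC)cc3)cc(OC)cc2OC)cc1`, 6.7 ug/mL
compound 3, `COc1ccc(/C=C/c2cc(OC)cc(OC)c2/C=C/C(=O)c2cccc(Cl)c2)cc1`, 3.3 ug/mL

In a functional assay on B16-F10 cells (Mus musculus) for antiproliferative activity, read by MTT assay, with a stated time of 48 h (on this read-out higher numbers stand for weaker inhibition and lower numbers for stronger inhibition), compound 3 gives the lowest of the three numbers. Its nearest neighbour is compound 2, and the gap is given by a 2.0-fold lower number from compound 2 to compound 3 (0.31 log units; beyond the scatter), a modest step. Compound 1 stands furthest away; the step of a 1.9-fold lower number from compound 1 to compound 2 (0.28 log units; within the scatter) lies within the scatter.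

Compound 4, `CCOc1ccc(C(=O)/C=C/c2c(/C=C/c3ccc(OC)cc3)cc(OC)cc2OC)cc1`, is the next case. The change from compound 3 is 4-ethoxyphenyl in place of 3-chlorophenyl on a carbonyl carbon. This runs the step from compound 2 to compound 3 backwards, with a shorter chain on the oxygen. The two relevant steps point in opposite directions: compound 2 to compound 3 gained a modest amount by exchanging an alkoxyphenyl for the chlorophenyl, while compound 1 to compound 2 moved only within the scatter when the alkoxy chain was shortened. A 4-ethoxyphenyl is therefore expected to land near compound 2, that is, a small to modest rise in the number relative to compound 3 in this assay, of about a 1.7-fold higher number from compound 3 to compound 4 (0.22 log units; within the scatter).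

Compound 4 is accordingly estimated at 5.5 ug/mL in this assay, with a range from 2.5 ug/mL to 12 ug/mL.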

Compound 4, half-maximal inhibitory concentration: 6.4 ug/mL
The estimate for compound 4 lay 1.2-fold (0.07 log units) below the measured number; the measured number falls inside the stated range.
By their numbers in this assay, from the lowest: compounds 3, 4, 2 and 1 (each within the scatter of the next, the first and the last beyond it).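

In this assay, placing 4-ethoxyphenyl on the carbonyl carbon in place of 3-chlorophenyl gives a result that stays inside the scatter (a 1.9-fold higher number from compound 3 to compound 4 (0.29 log units; within the scatter)), whereas the earlier exchange of 4-(1-methylbutoxy)phenyl for 3-chlorophenyl only just cleared it (a 2.0-fold lower number from compound 2 to compound 3 (0.31 log units; beyond the scatter)). The group on the oxygen shows no order by chain size in this small set: replacing the 1-methylbutyl group with ethyl changes nothing measurable (a 1.0-fold lower number from compound 2 to compound 4 (0.02 log units; within the scatter)), and the step from dodecyl to ethyl also remains inside the scatter (a 2.0-fold lower number from compound 1 to compound 4 (0.30 log units; within the scatter)). Nothing available here gives a measured basis for explaining these small steps.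

Chlorine and alkoxy appear here under different ring names, 3-chlorophenyl and 4-ethoxyphenyl, so the identity of the group and its place on the ring remain entangled, and 4-chlorophenyl and 3-ethoxyphenyl would be needed to separate them. From the compounds shown here alone, it also remains open whether a hydroxyl, a carboxylic acid or a dimethylamino group on this phenyl ring would give a step beyond the scatter from the alkoxy compounds.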